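The source may hold more compounds than are shown below. What is called first, only, known or untested is meant among the compounds shown, and "the series" means these compounds.

In a functional assay on HEK293 cells for agonist activity at G-protein coupled receptor 84 (Homo sapiens), read by calcium flux (on this read-out higher numbers stand for an effect only at larger amounts of compound and lower numbers for an effect already at smaller amounts), three compounds sharing one core differ only in the length of the chain on it. Compound 1 `CCCCCc1nc(O)cc(O)n1` gives 3670 nM, compound 2 `CCCCCCc1nc(O)cc(O)n1` gives 454 nM, and compound 3 `CCCCCCCCCc1nc(O)cc(O)n1` gives 48.7 nM, the lowest of the three numbers. Every measured step points one way: an 8.1-fold lower number from compound 1 to compound 2 (0.91 log units; beyond the scatter), a 9.3-fold lower number from compound 2 to compound 3 (0.97 log units; beyond the scatter) and a 75-fold lower number from compound 1 to compound 3 (1.88 log units; beyond the scatter). Compound 4 `CCCCCCCCc1nc(O)cc(O)n1` turns back by a single carbon: hydrogen in place of methyl on a saturated chain carbon, eight bonds along the chain from an aromatic carbon. Since the smaller of the lengthening steps was an 8.1-fold lower number from compound 1 to compound 2 (0.91 log units; beyond the scatter), removing one methyl is expected to raise the number in this assay beyond the scatter, though likely by less than that. Compound 4 is therefore estimated at 130 nM, within 50 nM to 400 nM, the expected step being a 2.7-fold higher number from compound 3 to compound 4 (0.43 log units; beyond the scatter).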

Compound 4, half-maximal effective concentration: 11.4 nM
The estimate for compound 4 lay 11-fold (1.06 log units) above the measured number, and the stated range ends above it.
By their numbers in this assay, from the lowest: compound 4; then compound 3; then compound 2; then compound 1.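

In this assay, removing the methyl on a saturated chain carbon, eight bonds along the chain from an aromatic carbon, reverses the earlier direction, giving a 4.3-fold lower number from compound 3 to compound 4 (0.63 log units; beyond the scatter). The lowest number of the series therefore belongs to a chain shorter than the longest one shown, with a 40-fold lower number from compound 2 to compound 4 (1.60 log units; beyond the scatter) and a 320-fold lower number from compound 1 to compound 4 (2.51 log units; beyond the scatter). Adding one carbon lowers the number at one chain length and raises it at another: the same change on two cores in this assay, an 8.1-fold lower number (0.91 log units; beyond the scatter) from compound 1 to compound 2 and a 4.3-fold higher number (0.63 log units; beyond the scatter) from compound 4 to compound 3, 35-fold (1.54 log units) apart, beyond the scatter of two such steps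

Going by these compounds, whether a longer chain would raise the number further remains open. So does what a carboxylic acid or an amine on that chain carbon would do.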